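Chloro for isopentyloxy: a working note on the series

A few compounds are considered here, and "the series" means these few. Any claim that something is new, unique, unknown or untested is made for them only; others in the source may bear on it.

Measured in a functional assay on A549 cells (Homo sapiens) for cytotoxicity, with a stated time of 48 h; a lower number here means a stronger inhibitor, a higher number a weaker inhibitor:
compound 1 `CC(C)COc1ccc2oc(/C=C/[S+](C)[O-])cc(=O)c2c1`: 1100 nM
compound 2 `CC(C)CCOc1ccc2oc(/C=C/[S+](C)[O-])cc(=O)c2c1`: 1000 nM

Alongside compound 1, compound 2 gives 1000 nM in this assay, and the two values lie within the scatter of each other. Among the compounds with values here, the only measured step, a 1.1-fold lower number from compound 1 to compound 2 (0.04 log units; within the scatter), is within the scatter and alters the chain alone. Compound 3 `C[S+]([O-])/C=C/c1cc(=O)c2cc(Cl)ccc2o1` differs from compound 2 at the same aromatic carbon: chloro in place of isopentyloxy on an aromatic carbon, chloro in place of isopentyloxy. Within the data shown here, no measured compound lacks the chain or carries chloro, so the one measured step sets no size for this change and gives no direction. Only a moderate move towards a weaker number is tentatively expected, and a step in the opposite direction remains possible. The estimated change is a 1.5-fold higher number from compound 2 to compound 3 (0.18 log units; within the scatter). Compound 3 is expected at 1500 nM, with an estimated range of 450 nM to 5000 nM.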

Compound 3, half-maximal inhibitory concentration: 1700 nM
Compound 3: the middle estimate sits 1.1-fold (0.05 log units) below what was measured; measured number inside the range.
By their numbers in this assay, from the lowest: compounds 2, 1 and 3 (each within the scatter of the next).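

In this assay, within the data shown here, the first change at this aromatic carbon that removes the ether chain altogether gives a 1.7-fold higher number from compound 2 to compound 3 (0.23 log units; within the scatter), and the matching comparison with the isobutoxy compound gives a 1.5-fold higher number from compound 1 to compound 3 (0.19 log units; within the scatter), both within the scatter. The earlier step altered only the chain, whereas these show that chloro can stand in place of either oxygen-linked chain with no change beyond the scatter, so neither chain is required for a value in this range. Nothing available bears on why these values stay so close.

Going by these compounds, whether an amine, a carboxylic acid or a longer chain on this carbon would move the number beyond the scatter remains open. On these data alone, the sulfur-bearing side chain is the same in all three compounds, so its contribution also remains untested.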